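This account rests on a few compounds, and the source may have more. Where it says the series, first, only, none or still open, it means among the compounds named here.

Measured compounds:
- compound 1, `CCc1ccccc1NS(=O)(=O)c1ccc(N2CCNC2=O)cc1` — 240 nM
- compound 3, `Cc1ccc(NS(=O)(=O)c2ccc(N3CCNC3=O)cc2)cc1` — 480 nM
- compound 2, `O=C1NCCN1c1ccc(S(=O)(=O)Nc2ccc(C3CCCCC3)cc2)cc1` — > 1000 nM, a limit of the assay rather than a number

In a functional assay on HT-29 cells (Homo sapiens) for antiproliferative activity, read by sulforhodamine B assay, with a stated time of 48 h (on this read-out lower numbers stand for stronger inhibition and higher numbers for weaker inhibition), compound 1 gives 240 nM, the lowest of the two plain numbers shown. Compound 3 sits nearest, and the step of a 2.0-fold higher number from compound 1 to compound 3 (0.30 log units; within the scatter) stays within the scatter. Compound 2 gives only a limit, > 1000 nM. The step of an at least 2.0-fold lower number from compound 2 to compound 3 (0.31 log units; beyond the scatter) shows that the methyl compound reaches a lower number than the cyclohexyl compound, to at least a modest extent; there is only the limit of > 1000 nM in this assay, at which 1 of the 3 values shown sits, behind the cyclohexyl side.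

Compound 4, `O=C1NCCN1c1ccc(S(=O)(=O)Nc2ccc(I)cc2)cc1`, differs from compound 1 in one place: 4-iodophenyl in place of 2-ethylphenyl on a sulfonamide nitrogen. Among the measured compounds shown here, two measured steps bear on this. Moving from 2-ethylphenyl to 4-methylphenyl changed little, and exchanging cyclohexyl for methyl on the aromatic carbon lowered the number. Compound 4 carries an iodine where compound 3 carries a methyl, so its number is expected to land near that of compound 3, with a step of a 1.9-fold higher number from compound 1 to compound 4 (0.27 log units; within the scatter) that is expected to stay about within the scatter. Compound 4 is therefore estimated at 450 nM, within 200 nM to 1300 nM.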

Compound 4, half-maximal inhibitory concentration: 650 nM
Compound 4: middle estimate off by 1.4-fold (0.16 log units), on the low side, within the range that was stated.
By their numbers in this assay, from the lowest: compounds 1, 3 and 4 (each within the scatter of the next, the first and the last beyond it). At a limit, above all of these: compound 2.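

In this assay, 4-iodophenyl in place of 2-ethylphenyl on the sulfonamide nitrogen gives a 2.7-fold higher number from compound 1 to compound 4 (0.43 log units; beyond the scatter), so this change at that position, unlike the move to 4-methylphenyl, goes modestly beyond the scatter. Iodo in place of methyl on the aromatic carbon gives a 1.4-fold higher number from compound 3 to compound 4 (0.13 log units; within the scatter), so the two groups cannot be told apart here. Iodo in place of cyclohexyl gives an at least 1.5-fold lower number from compound 2 to compound 4 (0.18 log units; that floor lies within the scatter), which cannot separate the two groups, as compound 2 stands at a limit of the assay: the limit of > 1000 nM in this assay, at which 1 of the 4 values shown sits.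

On these data alone, it remains open whether 4-ethylphenyl would give a number closer to compound 1 or to compound 4, which would separate the effect of the ethyl group from that of its place on the ring. As far as these compounds go, it is also open how an amine or a carboxylic acid on this ring would behave.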